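Swapping a hexyl chain for a methylated urea

The compounds below may be only part of what the source reports. "The series", "measured", "known", "first", "only" and "open" are said of these compounds alone.

Two compounds share one core and differ only at a nitrogen on an aromatic ring. Compound 1 `CCCNC(=O)Nc1c(OCCCn2cnc(-c3ccccc3)c2)cccc1N(C)C` carries a propylcarbamoyl group there, and in an assay on aorta for inhibition of acyl-CoA:cholesterol acyltransferase (Oryctolagus cuniculus) (a lower number here means a stronger inhibitor, a higher number a weaker inhibitor), compound 1 gives 7230 nM. Compound 2 `CCCCCCNc1c(OCCCn2cnc(-c3ccccc3)c2)cccc1N(C)C` carries a hexyl chain instead, and in this assay compound 2 gives 3300 nM. Going by the values given here, the single measured step, a 2.2-fold lower number from compound 1 to compound 2 (0.34 log units; beyond the scatter), is the only guide available, and it puts compound 2 at the lowest of the two numbers, with compound 1 as its nearest neighbour.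

Compound 3 `CCCCCN(C)C(=O)Nc1c(OCCCn2cnc(-c3ccccc3)c2)cccc1N(C)C` changes this position once more: methyl(pentyl)carbamoyl in place of hexyl on a nitrogen on an aromatic ring. The new group brings back a carbamoyl unit, as in compound 1, but with a methyl and a pentyl chain on its outer nitrogen rather than a single propyl chain and a hydrogen. Since the step from compound 1 to compound 2 removed a carbamoyl unit and lowered the number modestly, reintroducing one is expected to move the number partly back toward that of compound 1, giving an estimated step of a 1.5-fold higher number from compound 2 to compound 3 (0.18 log units; within the scatter). Compound 3 is therefore expected to give about 5000 nM in this assay, within a range of 2000 nM to 15000 nM.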

Compound 3, half-maximal inhibitory concentration: 280 nM
Beside the measured number, compound 3's estimate is 18-fold (1.25 log units) above it, and the stated range ends above it.
By their numbers in this assay, from the lowest: compound 3; then compound 2; then compound 1.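

This result changes how the earlier step reads: a carbamoyl unit at this nitrogen does not in itself bring a higher number, since in this assay methyl(pentyl)carbamoyl in place of hexyl gives a 12-fold lower number from compound 2 to compound 3 (1.07 log units; beyond the scatter), the opposite direction to what the carbamoyl-free hexyl seemed to suggest. Both ends of the comparison with the first urea carry the carbamoyl unit, so what sits on its outer nitrogen is what differs, and a methyl and a pentyl chain in place of a hydrogen and a propyl chain give a 26-fold lower number from compound 1 to compound 3 (1.41 log units; beyond the scatter), a far larger change than any earlier step at this position. Nothing available explains why these groups produce such a difference.

That last change altered two things at once, the hydrogen and the chain length, so a pentylcarbamoyl group with its hydrogen kept and a methyl(propyl)carbamoyl group would be needed to separate their shares. On these data alone, whether a longer chain such as octyl on the same outer nitrogen would lower the number further, or raise it again, also remains open.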